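From 4-Methylbenzyl to 2-Chlorophenyl on the Amide Nitrogen

This account rests on a few compounds, and the source may have more. Where it says the series, first, only, none or still open, it means among the compounds named here.

Measured compounds:
- compound 1 `CCOC(=O)[C@]1(C(=O)Nc2ccccc2Cl)C[C@@H]1c1cc(OC)c(OC)c(OC)c1` gives 34700 nM
- compound 2 `CCOC(=O)C1(C(=O)NCc2ccc(C)cc2)CC1c1cc(OC)c(OC)c(OC)c1` gives > 100000 nM; 37900 nM (2 entries)
- compound 3 `CCOC(=O)[C@@]1(C(=O)NCc2ccc(C)cc2)C[C@@H]1c1cc(OC)c(OC)c(OC)c1` gives > 100000 nM

In a functional assay on QGY cells (Homo sapiens) for cytotoxicity, read by MTT assay, with a stated time of 48 h (on this read-out higher numbers stand for weaker inhibition and lower numbers for stronger inhibition), compound 3 gives > 100000 nM, which is a limit of the assay rather than a number. Compound 3 therefore stands at the edge of what this assay reports, with no measured value of its own. Compound 2 carries the same 4-methylbenzyl group on an amide-type nitrogen and gives > 100000 nM; 37900 nM (2 entries); its drawing lacks the defined configuration that compound 3 carries (the fact that one of compounds 2 and 3 is drawn with a defined configuration and the other without, at the place where they differ).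

Compound 4 `CCOC(=O)[C@@]1(C(=O)Nc2ccccc2Cl)C[C@@H]1c1cc(OC)c(OC)c(OC)c1` has not been measured. It differs from compound 3 in a single place: 2-chlorophenyl in place of 4-methylbenzyl on an amide-type nitrogen. A useful point of comparison is compound 1, which also bears 2-chlorophenyl on an amide-type nitrogen and gives 34700 nM in this assay.

Going by the values given here, because compound 3 sits at a limit (the limit of > 100000 nM in this assay, at which 1 of the 3 values shown sits), no measured step can be drawn from it. The expected step from compound 3 to compound 4 is an at least 2.5-fold lower number from compound 3 to compound 4 (0.39 log units; beyond the scatter), toward stronger inhibition, guided by the value of compound 1 34700 nM. Compound 4 is estimated at 40000 nM, with a range from 15000 nM to 150000 nM.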

Compound 4, half-maximal inhibitory concentration: > 100000 nM
Compound 4: only a limit was reported; the forecaster's own chance of this, stated with the estimate: 35%; middle value at least 2.5-fold (0.39 log units) from the limit.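

The step from compound 3 to compound 4 cannot be read, since both compounds stand at a limit of this assay: the limit of > 100000 nM in this assay, at which 2 of the 4 values shown sit. The new information concerns configuration: with 2-chlorophenyl kept on the amide-type nitrogen, changing one stereocentre at a saturated ring carbon from R to S gives an at least 2.8-fold higher number from compound 1 to compound 4 (0.45 log units; beyond the scatter), and nothing else in the structure changes: the fact that compounds 1 and 4 differ only in the configuration as drawn. Within this small set, then, 2-chlorophenyl in place of 4-methylbenzyl does not by itself bring a measured value into range, and the drawn configuration has to be considered together with the group on the nitrogen.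

Compound 2 cannot show whether the 4-methylbenzyl compounds depend on configuration in the same way, since its configuration is undefined: the fact that one of compounds 2 and 3 is drawn with a defined configuration and the other without, at the place where they differ. Also open, going by these compounds, is how the configuration at this ring carbon would behave with a different group on the amide-type nitrogen, such as a hexyl chain.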